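The source may hold more compounds than are shown below. What is called first, only, known or untested is meant among the compounds shown, and "the series" means these compounds.

Compound 1 `COc1ccc(-c2cs/c(=N\NC(=O)c3ccc(O)cc3)n2-c2ccc(OC)cc2OC)cc1`: 2820 nM
Compound 2 `O=C(N/N=c1\scc(-c2ccc(Cl)cc2)n1-c1ccc(Cl)cc1Cl)c1ccc(O)cc1`: 2820 nM

Both numbers come from a functional assay on SF-295 cells (Homo sapiens) for cytotoxicity, read by sulforhodamine B assay, with a stated time of 48 h; a higher number here means a weaker inhibitor of growth, a lower number a stronger inhibitor of growth. Compound 2 stands level with compound 1 at the digits shown; the gap between them lies within the scatter, so neither compound can be called the stronger grower-inhibitor. Compound 3 `COc1ccc(-n2c(-c3ccc(Cl)cc3)cs/c2=N\NC(=O)c2ccc(O)cc2)c(OC)c1` still awaits measurement in this assay. It differs from compound 2 in one place: 2,4-dimethoxyphenyl in place of 2,4-dichlorophenyl on an aromatic nitrogen, the nitrogen of the five-membered aromatic ring with one nitrogen and one sulfur, two ring bonds from the ring sulfur, next to the ring atom that bears a 4-chlorophenyl group. Compound 3 thus carries the nitrogen-bound group of compound 1 together with the 4-chlorophenyl group of compound 2.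

Within the data shown here, no two measured compounds differ in a single place, so no measured step isolates this exchange. Compound 1 and compound 2 differ in two groups yet give matching values, so swapping one of them is expected to change little. The expected step is no change at the digits printed from compound 2 to compound 3 (within the scatter), none beyond the scatter. Compound 3 is estimated at 2820 nM, within a range from 1400 nM to 5700 nM.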

Compound 3, concentration for 50% growth inhibition: 27500 nM
Compound 3: the middle estimate sits 9.8-fold (0.99 log units) below what was measured; measured number above the stated range.
By their numbers in this assay, from the lowest: compounds 1 and 2 (each within the scatter of the next); then compound 3.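

In this assay, placing 2,4-dimethoxyphenyl in place of 2,4-dichlorophenyl on the aromatic nitrogen, with the 4-chlorophenyl group kept, gives a 9.8-fold higher number from compound 2 to compound 3 (0.99 log units; beyond the scatter), so the group at this position can matter for growth inhibition. With 2,4-dimethoxyphenyl kept on the nitrogen, chloro in place of methoxy on an aromatic carbon gives a 9.8-fold higher number from compound 1 to compound 3 (0.99 log units; beyond the scatter), so this second single change also weakens growth inhibition. Each group's effect therefore depends on its partner elsewhere in the molecule, something the matching values of the two earlier compounds could not reveal, and nothing here says what lies behind these steps.

The compounds shown leave open whether the loss belongs to the two methoxy groups together or to just one of them, and how a plain phenyl or a ring carrying an amine would behave on the same nitrogen. They also leave open whether this dependence between the two sites extends beyond these three compounds, or to other groups on the aromatic carbon, such as fluoro or methyl.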